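Swapping a Nitro for a Methoxy on the Aryl Ring

The source may report more compounds than this note shows. Statements on the series, on what has been measured and on what is new or still open speak of the compounds shown alone.

Measured so far:
compound 1 `CCCc1n[nH]c2c(=O)n(NC(=O)c3ccncc3)c(-c3cccc(OC)c3)nc12`, 9.13%
compound 2 `CCCc1n[nH]c2c(=O)n(NC(=O)c3ccccc3)c(-c3cccc([N+](=O)[O-])c3)nc12`, 27.8%

In a functional assay on DU-145 cells (Homo sapiens) for cytotoxicity, read by sulforhodamine B assay, with a stated time of 2 days, tested at 100 uM (a lower number here means less inhibition, a higher number more inhibition at the concentration tested (going by the name of the read-out)), compound 2 gives 27.8%, the higher of the two numbers seen. Compound 1 gives 9.13%, a gap that lies beyond the usual scatter, though the two compounds differ in more than one place, so no single change can be read from it.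

Compound 3 `CCCc1n[nH]c2c(=O)n(NC(=O)c3ccccc3)c(-c3cccc(OC)c3)nc12` has not yet been measured. Compared with compound 2 it changes as follows: methoxy in place of nitro on an aromatic carbon. It keeps the benzamide of compound 2 but carries the methoxy group of compound 1.

Since compound 1, which also carries methoxy, gives 9.13%, a downward step is expected here, of the size a number 15.8 percentage points lower from compound 2 to compound 3 (beyond the scatter), beyond the scatter. For compound 3 the expected value in this assay is 12%, between 3% and 25%.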

Compound 3, a percentage reported as inhibition, at one concentration (the size of the read-out at that concentration, not a potency): 23.6%
Beside the measured number, compound 3's estimate is 11.6 percentage points below it, within the range that was stated.
By their numbers in this assay, from the lowest: compound 1; then compounds 3 and 2 (each within the scatter of the next).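

In this assay, methoxy in place of nitro on an aromatic carbon gives a number 4.2 percentage points lower from compound 2 to compound 3 (within the scatter), so the 3-nitrophenyl and 3-methoxyphenyl versions cannot be told apart in this assay. The change that does register lies on the other side of the molecule: phenyl in place of pyridin-4-yl on a carbonyl carbon gives a number 14.5 percentage points higher from compound 1 to compound 3 (beyond the scatter), which ties the low number of compound 1 to its pyridin-4-yl group and not to its methoxy group. No measurement available here offers a reason for either step.

From the compounds shown here alone, it remains open how an amine or a carboxylic acid would read on this aromatic carbon, since only nitro and methoxy appear there. Going by these compounds, it is also open whether phenyl in place of pyridin-4-yl would give a similar step in a compound carrying nitro.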